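Aryl swap on the shared core: compound 1 to compound 4

The source may report more compounds than this note shows. Statements on the series, on what has been measured and on what is new or still open speak of the compounds shown alone.

Measured compounds in a functional assay on MCF7 cells (Homo sapiens) for cytotoxicity, read by MTT assay, with a stated time of 48 h; a higher number here means a weaker inhibitor, a lower number a stronger inhibitor:
compound 1 `Cc1ccc(-c2nnc(SCCn3c([N+](=O)[O-])cnc3C)o2)cc1`: 15500 nM
compound 2 `COc1cc(OC)cc(-c2nnc(SCCn3c([N+](=O)[O-])cnc3C)o2)c1`: 12800 nM
compound 3 `COc1cc(-c2nnc(SCCn3c([N+](=O)[O-])cnc3C)o2)cc(OC)c1OC`: 30600 nM

Compound 1 stands with its number within the scatter of compound 2 and of compound 3, so the three measured values are not separated. Going by the values given here, the only single-point step in the set, a 2.4-fold higher number from compound 2 to compound 3 (0.38 log units; beyond the scatter), concerns a methoxy added on an aromatic carbon and does not touch the aryl group that changes here.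

Compound 4 `Cc1ncc([N+](=O)[O-])n1CCSc1nnc(-c2cccs2)o1` differs from compound 1 in one place: thiophen-2-yl in place of 4-methylphenyl on an aromatic carbon. Among the compounds with values here, no measured pair shows this exchange, so no step beyond the scatter is expected, and a 1.0-fold lower number from compound 1 to compound 4 (0.01 log units; within the scatter) is the estimated step. Compound 4 is therefore expected to give about 15000 nM in this assay, with a range from 6000 nM to 38000 nM.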

Compound 4, half-maximal inhibitory concentration: 25800 nM
Compound 4: middle estimate off by 1.7-fold (0.24 log units), on the low side, and the stated range covers the measured number.
By their numbers in this assay, from the lowest: compounds 2, 1, 4 and 3 (each within the scatter of the next, the first and the last beyond it).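

The exchange of 4-methylphenyl for thiophen-2-yl on the shared core gives a 1.7-fold higher number from compound 1 to compound 4 (0.22 log units; within the scatter) in this assay, so at this position a five-membered aromatic ring with one sulfur is not separated from the six-membered carbon ring. The earlier compounds shown here carried only six-membered aromatic rings of carbon here and gave no reading of such an exchange. No available evidence bears on this result.

Open, going by these compounds, is how a cyclohexyl group, or a phenyl ring bearing an amine or a carboxylic acid, would read at this position in this assay.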